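Moving the oxane attachment point: compound 1 to compound 4

The source may report more compounds than this note shows. Statements on the series, on what has been measured and on what is new or still open speak of the compounds shown alone.

Compounds measured so far:
- compound 1 `O=C(Nc1ccc(C(F)(F)F)cc1)NC1CCN(C(=O)C2CCCOC2)CC1`: 1.1 ug/mL
- compound 2 `O=C(Nc1ccc(OC(F)(F)F)cc1)NC1CCN(C(=O)C2CCCOC2)CC1`: 94 ug/mL
- compound 3 `O=C(Nc1ccc(C(F)(F)F)c(F)c1)NC1CCN(C(=O)C2CCCOC2)CC1`: 11 ug/mL

In a physicochemical assay for solubility, read by mass spectrometry, in phosphate buffer, with a stated time of 24 h, at pH 7.4 (a lower number here means a less soluble compound, a higher number a more soluble compound), compound 1 gives 1.1 ug/mL, the lowest of the three numbers. Its nearest neighbour is compound 3, which gives 11 ug/mL, and furthest away is compound 2, which gives 94 ug/mL. The two measured steps are both changes on the aromatic ring: an 85-fold higher number from compound 1 to compound 2 (1.93 log units; beyond the scatter) and a 10-fold higher number from compound 1 to compound 3 (1.00 log units; beyond the scatter).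

Compound 4 `O=C(Nc1ccc(C(F)(F)F)cc1)NC1CCN(C(=O)C2CCOCC2)CC1` differs from compound 1 elsewhere: oxan-4-yl in place of oxan-3-yl on a carbonyl carbon. Neither measured step touches this part of the molecule, so there is no direct guide to how this assay will respond. The change keeps the same atoms and the same single ring oxygen, only joined differently, and on the strength of the data here no step beyond the scatter is expected in either direction. Compound 4 is therefore estimated to stay close to compound 1, with an expected step of a 1.4-fold higher number from compound 1 to compound 4 (0.13 log units; within the scatter) and a value of about 1.5 ug/mL, ranging from 0.4 ug/mL to 5 ug/mL.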

Compound 4, solubility: 17.6 ug/mL
Compound 4: the middle estimate sits 12-fold (1.07 log units) below what was measured; measured number outside the range, above it.
By their numbers in this assay, from the lowest: compound 1; then compounds 3 and 4 (each within the scatter of the next); then compound 2.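

In this assay, the change of attachment point alone gives a 16-fold higher number from compound 1 to compound 4 (1.20 log units; beyond the scatter), which shows that the read-out responds at this carbonyl position as well as on the aromatic ring, where both earlier changes lay. Oxan-3-yl and oxan-4-yl have the same heavy atoms, the same ring size and the same donor and acceptor counts, yet the step lies beyond the scatter, so these counts do not separate the two groups in this pair. No measurement given here bears on what lies behind this step.

The compounds shown leave open whether oxan-4-yl has a similar effect when the aromatic ring carries trifluoromethoxy or an added fluoro group. They also leave open how a piperidine ring, with an amine in place of the ring oxygen, or an open methoxyethyl chain would behave on the same carbonyl carbon.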